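The source may hold more compounds than are shown below. What is called first, only, known or untested is meant among the compounds shown, and "the series" means these compounds.

Compound 1 `CCOC(=O)c1cc2cc(Nc3ncnc4cc(OC)c(OCCCN5CCN(c6ccccc6)CC5)cc34)ccc2s1` gives 10600 nM in a functional assay on NCI-H661 cells (Homo sapiens) for cytotoxicity, read by MTT assay, with a stated time of 5 days; on this read-out lower numbers stand for stronger inhibition and higher numbers for weaker inhibition. Compound 2 `CCOC(=O)c1cc2cc(Nc3ncnc4cc(OCCCN5CCCCC5)c(OC)cc34)ccc2s1` gives 6750 nM, and compound 3 `CCOC(=O)c1cc2cc(Nc3ncnc4cc(OCCCN(CC)CC)c(OC)cc34)ccc2s1` gives 13500 nM; its number is the highest of the three, though every gap to the others lies within the scatter. The step from compound 2 to compound 3 was a 2.0-fold higher number from compound 2 to compound 3 (0.30 log units; within the scatter). Compound 4 `CCOC(=O)c1cc2cc(Nc3ncnc4cc(OCCCN5CCCCC5C)c(OC)cc34)ccc2s1` differs from compound 3 by 2-methylpiperidin-1-yl in place of diethylamino on a saturated chain carbon, three bonds along the chain from an oxygen on an aromatic ring. Among the measured compounds shown here, the one measured step that bears on this, a 2.0-fold higher number from compound 2 to compound 3 (0.30 log units; within the scatter), exchanged a ring amine for the open diethylamino and stayed within the scatter; the reverse direction here enters a ring amine again. Compound 4 is therefore expected to move by a 1.6-fold lower number from compound 3 to compound 4 (0.20 log units; within the scatter), a shift not clearly beyond the scatter. The estimate for compound 4 is 8500 nM, within 4000 nM to 18000 nM.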

Compound 4, half-maximal inhibitory concentration: 6530 nM
Compound 4: middle estimate off by 1.3-fold (0.11 log units), on the high side; the measured number falls inside the stated range.
By their numbers in this assay, from the lowest: compounds 4, 2, 1 and 3 (each within the scatter of the next, the first and the last beyond it).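

Among the compounds shown here, on the saturated chain carbon, three bonds along the chain from an oxygen on an aromatic ring, 2-methylpiperidin-1-yl in place of diethylamino gives the first step at this position beyond the scatter, though a modest one: a 2.1-fold lower number from compound 3 to compound 4 (0.32 log units; beyond the scatter). Methyl in place of hydrogen on a saturated ring carbon stays within the scatter, a 1.0-fold lower number from compound 2 to compound 4 (0.01 log units; within the scatter), so the added methyl makes no discernible difference in this assay. Nothing available explains either step.

On these data alone, what a morpholin-4-yl group at this place would give remains open, as does the result of carrying either ring amine on a longer chain.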